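Swapping a thiazole for a pyridine on two related cores

This account rests on a few compounds, and the source may have more. Where it says the series, first, only, none or still open, it means among the compounds named here.

Four compounds share a sulfonamide arm on a phenyl ring and differ in the core that carries this arm and in the ring attached to the sulfonamide nitrogen. Compound 1 `O=c1[nH]cnc2c1c(-c1ccccc1)cn2-c1ccc(S(=O)(=O)Nc2nccs2)cc1` and compound 2 `O=c1[nH]cnc2c1c(-c1ccccc1)cn2-c1ccc(S(=O)(=O)Nc2ccccn2)cc1` share one core; compound 3 `Nc1ncnc2c1c(-c1ccccc1)cn2-c1ccc(S(=O)(=O)Nc2nccs2)cc1` and compound 4 `Nc1ncnc2c1c(-c1ccccc1)cn2-c1ccc(S(=O)(=O)Nc2ccccn2)cc1` share another. The difference between the two cores is not broken down here.

In a functional assay on MCF7 cells (Homo sapiens) for inhibition, read by sulforhodamine B assay, with a stated time of 24 h (on this read-out higher numbers stand for weaker inhibition and lower numbers for stronger inhibition), compound 1 gives 6210 nM and compound 2 gives 5320 nM. The change between them is pyridin-2-yl in place of 1,3-thiazol-2-yl on a sulfonamide nitrogen, and it produced a 1.2-fold lower number from compound 1 to compound 2 (0.07 log units; within the scatter). In this assay compound 3 gives 6450 nM. The three measured values all lie within the scatter of one another, so no order among compounds 1, 2 and 3 can be read from them.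

Compound 4 carries the same change on the second core: pyridin-2-yl in place of 1,3-thiazol-2-yl on a sulfonamide nitrogen. The place of the change is described in the same words for both pairs, so the same size of step is the natural expectation. The step from compound 3 to compound 4 is therefore estimated at a 1.2-fold lower number from compound 3 to compound 4 (0.07 log units; within the scatter), resting on the measured 1.2-fold lower number from compound 1 to compound 2 (0.07 log units; within the scatter). Compound 4 is thus expected to give 5500 nM in this assay, with the estimate spanning from 2800 nM to 11000 nM. Whether this expectation holds is decided by the measurement of compound 4.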

Compound 4, half-maximal inhibitory concentration: 6340 nM
Compound 4: the middle estimate sits 1.2-fold (0.06 log units) below what was measured; the range from low to high includes it.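

In this assay, putting pyridin-2-yl in place of 1,3-thiazol-2-yl on the sulfonamide nitrogen of the core of compound 3 gives a 1.0-fold lower number from compound 3 to compound 4 (0.01 log units; within the scatter). Set beside the same change on the core of compound 1, the two steps do not differ: the same change on two cores in this assay, a 1.2-fold lower number (0.07 log units; within the scatter) from compound 1 to compound 2 and a 1.0-fold lower number (0.01 log units; within the scatter) from compound 3 to compound 4, 1.1-fold (0.06 log units) apart, within the scatter of two such steps. This shows that, across these two cores, the swap leaves the number within the scatter both times, but that is agreement between two steps too small to read as real effects, so it does not show that an effect of a measurable size carries from one core to the other, and two cores say nothing about any further core.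

The compounds shown leave open whether a different group on the sulfonamide nitrogen, such as a methyl group, a longer alkyl chain, or a pyridin-2-yl ring bearing an amine or a carboxylic acid, would move the number beyond the scatter at all. They also leave open whether a change with a clear effect on one of these cores would keep the same size on the other, which is the real test of carrying a change across cores.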